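Swapping the halogenated phenyl on a quinazoline-like core

The source may hold more compounds than are shown below. What is called first, only, known or untested is meant among the compounds shown, and "the series" means these compounds.

Three compounds share one core and differ only in the halogenated phenyl ring that sits on a nitrogen on an aromatic ring. Compound 1 `COc1cc2nc(N3CCC(N4CCCC4)CC3)nc(Nc3ccc(F)c(F)c3)c2cc1OC` carries a 3,4-difluorophenyl there; in an assay on isolated protein for displacement of a labelled ligand from C-C chemokine receptor type 4 (Homo sapiens), read by scintillation proximity assay (a lower number here means a stronger inhibitor, a higher number a weaker inhibitor), compound 1 gives "not determined" (no result reported), so it contributes no number. Within the data shown here, compound 2 `COc1cc2nc(N3CCC(N4CCCC4)CC3)nc(Nc3cccc(Br)c3)c2cc1OC` carries a 3-bromophenyl and is the only member with a measured result: in this assay compound 2 gives 510 nM. Among the measured compounds shown here, with one number in hand, compound 2 stands alone; there is no second measured compound against which to rank it.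

Compound 3 `COc1cc2nc(N3CCC(N4CCCC4)CC3)nc(Nc3ccc(Cl)cc3)c2cc1OC` is the next step. The change is 4-chlorophenyl in place of 3-bromophenyl on a nitrogen on an aromatic ring. For the measured compounds named here, no pair of measured compounds shows what such a halogen swap does on this core, so the direction of the step is open. Going by the values given here, an expectation built only on the single value of compound 2 510 nM is that the shift from compound 2 to compound 3 stays modest, with a slightly weaker binder somewhat more likely than a stronger one, as the estimated step of a 1.5-fold higher number from compound 2 to compound 3 (0.17 log units; within the scatter) expresses. Compound 3 is therefore expected to give about 750 nM, plausibly anywhere from 200 nM to 2800 nM.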

Compound 3, half-maximal inhibitory concentration: 150 nM
Compound 3: the middle estimate sits 5.0-fold (0.70 log units) above what was measured; the whole stated range lies above it.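

The halogenated phenyl ring on the nitrogen now has its first measured comparison: in this assay, 4-chlorophenyl in place of 3-bromophenyl gives a 3.4-fold lower number from compound 2 to compound 3 (0.53 log units; beyond the scatter), so the read-out does respond to a change at this place. The two groups match in heavy-atom count, in their carbon-only aromatic ring, in hydrogen-bond donors and acceptors, and in net charge, which leaves the identity of the halogen and its place on the ring as the differences between them. No measurement shown here explains why the number falls.

As far as these compounds go, compound 1 has no number, so its steps cannot be read and the standing of its 3,4-difluorophenyl remains unknown. This single swap changes the halogen and its place on the ring together, so it cannot tell which of the two matters, and it leaves open how the shared core would respond to a phenyl ring carrying a methoxy group or an amine instead of a halogen.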